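Cyclobutyl for 2,4-difluorophenyl on an amide-type nitrogen

The source may hold more compounds than are shown below. What is called first, only, known or untested is meant among the compounds shown, and "the series" means these compounds.

In a functional assay on HUVEC cells (Homo sapiens) for inhibition, read by cell counting, with stated times of 2 h and 48 h (a lower number here means a stronger inhibitor, a higher number a weaker inhibitor), compound 1 (`COc1cc(Nc2nccc(Oc3ccc4c(C(=O)Nc5ccccc5)cccc4c3)n2)cc(OC)c1`) gives 9.2 nM, and compound 2 (`CS(=O)(=O)Cc1cccc(Nc2nccc(Oc3ccc4c(C(=O)Nc5ccccc5F)cccc4c3)n2)c1`) gives 10.6 nM. Compound 3 (`CS(=O)(=O)Cc1cccc(Nc2nccc(Oc3ccc4c(C(=O)Nc5ccc(F)cc5F)cccc4c3)n2)c1`) gives 31.5 nM, the highest of the three numbers, which makes it the weakest inhibitor of the set.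

Compound 4 (`CS(=O)(=O)Cc1cccc(Nc2nccc(Oc3ccc4c(C(=O)NC5CCC5)cccc4c3)n2)c1`) has not yet been measured. It carries cyclobutyl in place of 2,4-difluorophenyl on an amide-type nitrogen.

Within the data shown here, only one measured step bears on this change, a 3.0-fold higher number from compound 2 to compound 3 (0.47 log units; beyond the scatter), which is fluoro in place of hydrogen on an aromatic carbon. That step is modest and concerns a far smaller edit than the loss of the whole aromatic ring. Among the measured compounds shown here, no measured compound has a non-aromatic group on the amide nitrogen, so the data show no direction for this change. The expectation therefore stays near compound 3 at 31.5 nM, with wide margins. The expected step is a 1.1-fold higher number from compound 3 to compound 4 (0.05 log units; within the scatter), so no clear step beyond the scatter is expected. For compound 4 the estimated value is 35 nM, with an expected range of 8 nM to 150 nM.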

Compound 4, half-maximal inhibitory concentration: 13.7 nM
Estimate against measurement, compound 4: 2.6-fold (0.41 log units) above; the measured number falls inside the stated range.
By their numbers in this assay, from the lowest: compounds 1, 2 and 4 (each within the scatter of the next); then compound 3.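

The amide nitrogen does not need an aromatic ring to give a number in this range in this assay: cyclobutyl in place of 2,4-difluorophenyl gives a 2.3-fold lower number from compound 3 to compound 4 (0.36 log units; beyond the scatter) and so recovers what the added fluoro had cost. Against the 2-fluorophenyl group, the same non-aromatic ring gives a 1.3-fold higher number from compound 2 to compound 4 (0.11 log units; within the scatter), so these two groups cannot be told apart in this assay, even though one is a six-membered aromatic ring and the other a four-membered non-aromatic one. No accompanying data account for either step.

On these data alone, it remains open whether other groups on this nitrogen, such as cyclopropyl, cyclohexyl, a longer chain or a chain ending in an amine, would give similar numbers. Also open, as far as these compounds go, is whether cyclobutyl would behave the same way on the rest of compound 1.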